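A few compounds are considered here, and "the series" means these few. Any claim that something is new, unique, unknown or untested is made for them only; others in the source may bear on it.

The series shares one core, carried here by compound 1 `C=C(C)CCC[C@]1(C)C2=CCC[C@](C)(C[C@@H](O)c3ccoc3)[C@H]2CC[C@H]1C`. In a functional assay on HL-60 cells (Homo sapiens) for antiproliferative activity, read by XTT assay, with a stated time of 72 h (on this read-out higher numbers stand for weaker inhibition and lower numbers for stronger inhibition), compound 1 gives 31200 nM. Compound 2 `C=C(C)CCC[C@]1(C)C2=CCC[C@](C)(C[C@H](O)c3ccoc3)[C@H]2CC[C@H]1C` gives 31200 nM in this assay; the step of no change at the digits printed from compound 1 to compound 2 (within the scatter), and the fact that compounds 1 and 2 differ only in the configuration as drawn is the whole distinction between that pair. Compound 3 `C=C(C)CC[C@]1(C)C2=CCC[C@](C)(C[C@@H](OC(C)=O)C3=CC(=O)OC3O)[C@H]2CC[C@H]1C` differs from compound 1 in several places at once. In this assay compound 3 gives 3300 nM. On the numbers shown compound 1 stands level with compound 2 at the top of the three, with compound 3 furthest away and lower, beyond the scatter.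

Compound 4 `C=C(C)CCC[C@]1(C)C2=CCC[C@](C)(C[C@@H](O)C3=CC(=O)OC3O)[C@H]2CC[C@H]1C` is compound 1 with a group of 7 heavy atoms (4 carbon, 3 oxygen; one five-membered non-aromatic ring with 1 hetero atom) in place of a group of 5 heavy atoms (4 carbon, 1 oxygen; one five-membered aromatic ring with 1 hetero atom), on a saturated chain carbon bound to an oxygen on a saturated carbon and a saturated chain carbon. Among the compounds with values here, no measured step isolates this change: the step of no change at the digits printed from compound 1 to compound 2 (within the scatter) concerns configuration alone and does not bear on it, and compound 3 is separated from compound 1 by more than this one change. The values of compound 3 and compound 1 point toward lower numbers where the five-membered non-aromatic ring is present, so a step of that order is expected, a 6.2-fold lower number from compound 1 to compound 4 (0.80 log units; beyond the scatter). For compound 4 a value of 5000 nM is estimated, in the range 1500 nM to 20000 nM.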

Compound 4, half-maximal inhibitory concentration: 3200 nM
Compound 4: middle estimate off by 1.6-fold (0.19 log units), on the high side, and the stated range covers the measured number.
By their numbers in this assay, from the lowest: compounds 4 and 3 (each within the scatter of the next); then compounds 1 and 2 (each within the scatter of the next).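

In this assay, the exchange of furan-3-yl for the five-membered non-aromatic ring group can now be read on its own, which compound 3 did not allow: a 9.8-fold lower number from compound 1 to compound 4 (0.99 log units; beyond the scatter). Read from the other configuration, the change gives a step of the same printed size, a 9.8-fold lower number from compound 2 to compound 4 (0.99 log units; beyond the scatter), and the two furan-3-yl compounds stand apart only as follows: the fact that compounds 1 and 2 differ only in the configuration as drawn. At this saturated chain carbon, the ring exchange therefore moves the number beyond the scatter, whereas the configuration change within the furan-3-yl pair does not.

From the compounds shown here alone, whether configuration at this carbon matters once the non-aromatic ring is present remains open. Also open, going by these compounds, is whether an amine or a carboxylic acid in place of that ring would give a number like that of compound 4.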